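A Methyl Group Removed from the Cyclopropyl Amide

A few compounds are considered here, and "the series" means these few. Any claim that something is new, unique, unknown or untested is made for them only; others in the source may bear on it.

Compound 1 `CNC(=O)c1cc(C(=O)N[C@H]2[C@@H]3C[C@H](O)C[C@@H]32)cc2c1OC[C@@]2(C)c1ccccc1` gives 3.7 in a physicochemical assay for lipophilicity, at pH 7.4; a higher number here means a more lipophilic compound, a lower number a more polar compound
Compound 2 `CNC(=O)c1cc(C(=O)N[C@H]2C[C@@H]2C)cc2c1OC[C@@]2(C)c1ccccc1` gives 4.7 in this assay

Compound 2 holds the higher of these two numbers, and its gap to compound 1 lies beyond the scatter. Compound 3 `CNC(=O)c1cc(C(=O)NC2CC2)cc2c1OC[C@@]2(C)c1ccccc1` has not yet been measured. It differs from compound 2 by one change (hydrogen in place of methyl on a saturated ring carbon), hydrogen in place of methyl on a saturated ring carbon, which turns 2-methylcyclopropyl into cyclopropyl. Among the measured compounds shown here, only one measured step bears on this (a number 1.00 log units higher from compound 1 to compound 2 (beyond the scatter)). That step exchanged a whole group on an amide-type nitrogen, and the departing group carried an oxygen, so it offers only a loose guide to size and none to direction. A small fall is expected in this assay and the estimated change (a number 0.40 log units lower from compound 2 to compound 3 (beyond the scatter)) is well under that step. The expected value for compound 3 is 4.3 with an estimated range (3.9 to 4.6).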

Compound 3, distribution coefficient: 4
Estimate against measurement, compound 3: 0.30 log units above; the range from low to high includes it.
By their numbers in this assay, from the lowest: compounds 1 and 3 (each within the scatter of the next); then compound 2.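

With hydrogen in place of methyl on a saturated ring carbon, this assay gave a number 0.70 log units lower from compound 2 to compound 3 (beyond the scatter), so this single carbon on the cyclopropyl ring shifts the reading by more than the scatter. The much larger oxygen-bearing group on the amide-type nitrogen and the plain cyclopropyl group stand only a number 0.30 log units higher from compound 1 to compound 3 (within the scatter) apart, so the earlier a number 1.00 log units higher from compound 1 to compound 2 (beyond the scatter) can no longer be read as a contrast set by that oxygen-bearing group alone. No evidence is available to explain either result.

The compounds shown leave open how the reading responds to other groups on this nitrogen, such as a cyclobutyl ring, an ethyl chain or an amine. They also leave the hydroxyl group of compound 1 and its five-membered ring unseparated.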